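Trifluoromethyl in place of hydroxy: a question of tolerance

The source may hold more compounds than are shown below. What is called first, only, known or untested is meant among the compounds shown, and "the series" means these compounds.

Three compounds sharing one core differ only in a single group, and they are compared in an ADME assay on HEK293 cells (Homo sapiens) for cytotoxicity, read by resazurin assay, with a stated time of 48 h; a higher number here means that more compound is tolerated, a lower number that less compound is tolerated. Compound 1 (`Cc1ccc(S(=O)(=O)Nc2ccc3oc(-c4ccccc4)nc3c2)cc1`) gives 75000 nM, and compound 2 (`COc1ccc(S(=O)(=O)Nc2ccc3oc(-c4ccccc4)nc3c2)cc1`) gives 91000 nM. Swapping the group between them produces a 1.2-fold higher number from compound 1 to compound 2 (0.08 log units; within the scatter).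

Compound 3 (`O=S(=O)(Nc1ccc2oc(-c3ccccc3)nc2c1)c1ccc(O)cc1`) gives > 100000 nM, which is a limit of the assay and not a number. The steps leading to it are an at least 1.3-fold higher number from compound 1 to compound 3 (0.12 log units; that floor lies within the scatter) and an at least 1.0-fold higher number from compound 2 to compound 3 (0.04 log units; that floor lies within the scatter), so compound 3 cannot be set apart from the other two on these numbers.

Compound 4 (`O=S(=O)(Nc1ccc2oc(-c3ccccc3)nc2c1)c1ccc(C(F)(F)F)cc1`) has trifluoromethyl in place of hydroxy on an aromatic carbon. All three measured swaps concern this same place, and none goes beyond the scatter, so a large change is not expected here. Trifluoromethyl itself is untested, which leaves the estimate wide and reaching lower than any measured value. The expected result is no step beyond the scatter, namely an at least 1.6-fold lower number from compound 3 to compound 4 (0.22 log units; that floor lies within the scatter). For compound 4 the estimated value is 60000 nM, with an expected range from 25000 nM to 100000 nM.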

Compound 4, half-maximal cytotoxic concentration: 74000 nM
The estimate for compound 4 lay 1.2-fold (0.09 log units) below the measured number; the range from low to high includes it.
By their numbers in this assay, from the lowest: compounds 4, 1 and 2 (each within the scatter of the next). At a limit, above all of these: compound 3.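

In this assay, trifluoromethyl brings four heavy atoms and no hydrogen-bond donor or acceptor to this aromatic carbon, yet compound 4 cannot be told apart from the compounds carrying methoxy or methyl: the steps are a 1.2-fold lower number from compound 2 to compound 4 (0.09 log units; within the scatter) and a 1.0-fold lower number from compound 1 to compound 4 (0.01 log units; within the scatter). Against the hydroxy group, the comparison gives an at least 1.3-fold lower number from compound 3 to compound 4 (0.13 log units; that floor lies within the scatter), which is only a floor. That step stays a floor because compound 3 sits at a limit of the assay: the limit of > 100000 nM in this assay, at which 1 of the 4 values shown sits.

Going by these compounds, whether a group of another kind at this place, such as an amine or a carboxylic acid, would produce a step beyond the scatter remains open. The true value of compound 3 is also unknown, so how far it lies from the other three compounds cannot be said.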